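The source may hold more compounds than are shown below. What is called first, only, known or untested is meant among the compounds shown, and "the series" means these compounds.

In a physicochemical assay for solubility, read by spectrophotometry, in phosphate buffer, with a stated time of 18 h, at pH 7.4 (a higher number here means a more soluble compound, a lower number a less soluble compound), two compounds of the series have been read so far. Compound 1 (`CCc1ccc(-c2nc3c(c(C)nn3-c3ccccc3)c(-c3ccccc3[N+](=O)[O-])c2C#N)cc1`) gives 1200 nM, and compound 2 (`Cc1ccccc1-c1nc2c(c(C)nn2-c2ccccc2)c(-c2ccccc2O)c1C#N`) gives 21000 nM. Compound 2 therefore holds the higher of the two numbers, and the gap to compound 1 lies beyond the scatter. The two compounds differ in more than one place, so no single structural change can be read from this pair.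

Compound 3 (`Cc1nn(-c2ccccc2)c2nc(-c3ccc(Cl)cc3)c(C#N)c(-c3ccccc3O)c12`) keeps the 2-hydroxyphenyl group of compound 2 and carries 4-chlorophenyl in place of 2-methylphenyl, on an aromatic carbon next to the ring nitrogen and ortho to a cyano group: 4-chlorophenyl in place of 2-methylphenyl on an aromatic carbon. Within the data shown here, no measured step isolates this exchange, so the expectation rests on thin evidence. Compound 1, which also lacks the 2-methylphenyl group, reads 1200 nM, and this weakly suggests a downward move in this assay. A modest fall, only slightly beyond the scatter, is expected, with an estimated 2.6-fold lower number from compound 2 to compound 3 (0.42 log units; beyond the scatter). The estimated value for compound 3 is 8000 nM, with an expected range of 2500 nM to 25000 nM.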

Compound 3, solubility: 3800 nM
Compound 3: middle estimate off by 2.1-fold (0.32 log units), on the high side, within the range that was stated.
By their numbers in this assay, from the lowest: compound 1; then compound 3; then compound 2.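

In this assay, among these compounds, 4-chlorophenyl in place of 2-methylphenyl, on an aromatic carbon next to the ring nitrogen and ortho to a cyano group, gives the first step that can be read at a single place: a 5.5-fold lower number from compound 2 to compound 3 (0.74 log units; beyond the scatter). This position therefore responds to an exchange between two groups that match in heavy atoms, hydrogen-bond donors, hydrogen-bond acceptors and net charge, so those counts do not separate the two compounds. Among the compounds shown here, nothing measured so far bears on the reason for this fall.

The single step moves the methyl and introduces the chlorine together, so the compounds shown cannot separate the loss of 2-methylphenyl from the entry of 4-chlorophenyl, and steps to compound 1 cannot be read because it differs from compound 2 and compound 3 in more than one place. Open too, from the compounds shown here alone, is how this position would read with 4-methylphenyl or 2-chlorophenyl, which would split the exchange, or with a phenyl ring carrying an amine or a carboxylic acid.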